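A few compounds are considered here, and "the series" means these few. Any claim that something is new, unique, unknown or untested is made for them only; others in the source may bear on it.

In an assay on isolated protein for inhibition of cathepsin S (Homo sapiens), read by fluorescence, with a stated time of 20 min (on this read-out lower numbers stand for stronger inhibition and higher numbers for weaker inhibition), compound 3 `N#CC1(NC(=O)[C@@H]2C[C@@H](S(=O)(=O)c3ccccc3)C[C@H]2C(=O)N2CC3CCC(C2)O3)CC1` gives 1 nM, the lowest number of the three measured; compound 2 `N#CC1(NC(=O)[C@@H]2C[C@@H](S(=O)(=O)c3ccccc3)C[C@H]2C(=O)N2CCOCC2)CCC1` gives 4 nM in this assay, and compound 1 `N#CCNC(=O)[C@@H]1CC(F)(F)C[C@H]1C(=O)N1CCOCC1` gives 830 nM, both steps beyond the scatter, so compound 3 is the strongest inhibitor here. Compound 4 `N#CC1(NC(=O)[C@@H]2C[C@@H](S(=O)(=O)c3ccccc3)C[C@H]2C(=O)N2CCNCC2)CC1` differs from compound 3 by a group of 6 heavy atoms (4 carbon, 2 nitrogen; one six-membered non-aromatic ring with 2 hetero atoms) in place of a group of 8 heavy atoms (6 carbon, 1 nitrogen, 1 oxygen; one five-membered non-aromatic ring with 1 hetero atom, one six-membered non-aromatic ring with 2 hetero atoms), on a carbonyl carbon, so that the piperazin-1-yl group sits on the carbonyl carbon. For the measured compounds named here, no measured pair shows this exact change, so its effect is uncertain, but compound 2 with a smaller six-membered ring on that carbonyl gives 4 nM in this assay, a moderate loss. Compound 4 is therefore expected to lose potency by about a 5.0-fold higher number from compound 3 to compound 4 (0.70 log units; beyond the scatter). Compound 4 is estimated at 5 nM, within a range of 1.5 nM to 15 nM.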

Compound 4, half-maximal inhibitory concentration: 11 nM
Estimate against measurement, compound 4: 2.2-fold (0.34 log units) below; measured number inside the range.
By their numbers in this assay, from the lowest: compound 3; then compound 2; then compound 4; then compound 1.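

In this assay, for the compounds shown here, placing piperazin-1-yl on the carbonyl carbon in place of the two-ring group gives an 11-fold higher number from compound 3 to compound 4 (1.04 log units; beyond the scatter), the first direct reading of this position with the rest of the molecule unchanged. The group on this carbonyl carbon therefore clearly affects the number, and this large step comes with fewer heavy atoms, one ring fewer and one added hydrogen-bond donor. No available evidence separates these differences as the source of the step. Still open, as far as these compounds go, is how 4-methylpiperazin-1-yl or piperidin-1-yl would compare at this carbonyl carbon, which could help separate them.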